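From Dichlorophenyl to Dihydroxyphenyl in a Cytotoxic Series

The compounds below may be only part of what the source reports. "The series", "measured", "known", "first", "only" and "open" are said of these compounds alone.

Measured so far in a functional assay on SW-620 cells (Homo sapiens) for cytotoxicity, read by MTT assay, with a stated time of 72 h; a higher number here means a weaker inhibitor, a lower number a stronger inhibitor:
Compound 1 `COc1ccc(/C=C2\CCC/C(=C\c3ccc(Br)cc3)C2=O)cc1OC`: 5200 nM
Compound 2 `COc1ccc(/C=C2\CCC/C(=C\c3ccc(O)cc3)C2=O)cc1OC`: 7700 nM
Compound 3 `COc1ccc(/C=C2\CCC/C(=C\c3ccc(Cl)cc3Cl)C2=O)cc1OC`: 10300 nM

Compound 3 is not clearly separated from either of the other two compounds. The data show a 2.0-fold higher number from compound 1 to compound 3 (0.30 log units; within the scatter) and a 1.3-fold higher number from compound 2 to compound 3 (0.13 log units; within the scatter). The remaining measured step, a 1.5-fold higher number from compound 1 to compound 2 (0.17 log units; within the scatter), tells the same story, so these three compounds cannot be ranked.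

Compound 4 `COc1ccc(/C=C2\CCC/C(=C\c3ccc(O)c(O)c3)C2=O)cc1OC` keeps the shared core and differs from compound 3 in one group: 3,4-dihydroxyphenyl in place of 2,4-dichlorophenyl on a double-bonded chain carbon bound to a double-bonded ring carbon. The nearest evidence comes from compound 2, which carries 4-hydroxyphenyl at this place. Its exchange for 2,4-dichlorophenyl gave only a 1.3-fold higher number from compound 2 to compound 3 (0.13 log units; within the scatter). The exchange of 4-bromophenyl for the same group gave a 2.0-fold higher number from compound 1 to compound 3 (0.30 log units; within the scatter). Among the measured compounds shown here, no measured compound carries 3,4-dihydroxyphenyl, so the effect of this group on the value is unknown. On this evidence, no step beyond the scatter is expected in this assay. The expected step is a 1.6-fold lower number from compound 3 to compound 4 (0.20 log units; within the scatter). The estimate for compound 4 is 6500 nM, with an expected range of 2500 nM to 14000 nM.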

Compound 4, half-maximal inhibitory concentration: 10500 nM
Beside the measured number, compound 4's estimate is 1.6-fold (0.21 log units) below it; measured number inside the range.
By their numbers in this assay, from the lowest: compounds 1, 2, 3 and 4 (each within the scatter of the next, the first and the last beyond it).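

In this assay, replacing 2,4-dichlorophenyl with 3,4-dihydroxyphenyl on the double-bonded chain carbon bound to a double-bonded ring carbon leaves the two compounds within the scatter of each other (a 1.0-fold higher number from compound 3 to compound 4 (0.01 log units; within the scatter)). Thus, a ring with hydrogen-bond donors and acceptors cannot be told apart here from a ring with none, although both groups have the same heavy-atom count. Among the compounds shown here, the added hydroxy on an aromatic carbon also gives no separation (a 1.4-fold higher number from compound 2 to compound 4 (0.13 log units; within the scatter)), whereas the exchange of 4-bromophenyl for 3,4-dihydroxyphenyl gives the first step to pass beyond the scatter, a modest one (a 2.0-fold higher number from compound 1 to compound 4 (0.31 log units; beyond the scatter)).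

No measurement among those shown accounts for any of these steps. It remains open whether an amine, a carboxylic acid or a longer chain at this place would give a clearer step in this assay, since every group shown here is a substituted phenyl ring and all four compounds lie close together.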